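Moving a fluorine on the piperazine benzyl arm

The source may hold more compounds than are shown below. What is called first, only, known or untested is meant among the compounds shown, and "the series" means these compounds.

Of the compounds shown here, three of one series have been measured in a functional assay on MCF7 cells (Homo sapiens) for antiproliferative activity, read by sulforhodamine B assay, with a stated time of 72 h; on this read-out lower numbers stand for stronger inhibition and higher numbers for weaker inhibition. Compound 1 `Fc1ccccc1COc1ccc(-c2cc(CN3CCN(Cc4ccc(C(F)(F)F)cc4)CC3)no2)cc1` gives 3000 nM there. Compound 2 `Fc1ccc(COc2ccc(-c3cc(CN4CCN(Cc5ccc(C(F)(F)F)cc5)CC4)no3)cc2)cc1` gives 7900 nM in this assay, and compound 3 `N#Cc1cccc(COc2ccc(-c3cc(CN4CCN(Cc5ccc(F)cc5)CC4)no3)cc2)c1` gives 1800 nM. The difference between the cores of compound 3 and compound 2 is not broken down here; compound 3 and compound 1 are within the scatter of each other, while compound 2 stands beyond the scatter from compound 3.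

Compound 1 differs from compound 2 by 2-fluorophenyl in place of 4-fluorophenyl on a saturated chain carbon bound to an oxygen on an aromatic ring. That change produced a 2.6-fold lower number from compound 2 to compound 1 (0.42 log units; beyond the scatter).

Compound 4 `N#Cc1cccc(COc2ccc(-c3cc(CN4CCN(Cc5ccccc5F)CC4)no3)cc2)c1` is not yet measured. It differs from compound 3 by 2-fluorophenyl in place of 4-fluorophenyl on a saturated chain carbon bound to an amine nitrogen in a ring. Among the measured compounds shown here, the change is of the same kind as the one between compound 2 and compound 1, but it is not the same: in the earlier pair the place is on a saturated chain carbon bound to an oxygen on an aromatic ring, whereas here it is on a saturated chain carbon bound to an amine nitrogen in a ring. For the measured compounds named here, only one example of this kind of change exists among the measured compounds, so the expectation for compound 4 rests on a single step at a different place. The step from compound 3 to compound 4 is expected to be a 1.6-fold lower number from compound 3 to compound 4 (0.21 log units; within the scatter), somewhat smaller than the measured one, because the earlier pair gave a 2.6-fold lower number from compound 2 to compound 1 (0.42 log units; beyond the scatter) at another place. Compound 4 is estimated to give 1100 nM in this assay, with a likely range from 400 nM to 3200 nM.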

Compound 4, half-maximal inhibitory concentration: 1400 nM
Beside the measured number, compound 4's estimate is 1.3-fold (0.10 log units) below it; low and high end bracket the measured number.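

In this assay, 2-fluorophenyl in place of 4-fluorophenyl on a saturated chain carbon bound to an amine nitrogen in a ring gave a 1.3-fold lower number from compound 3 to compound 4 (0.11 log units; within the scatter), so on this core the change cannot be told apart from no change at all. Set beside the earlier pair, the two steps do not differ by more than the scatter allows: the same change on two cores in this assay, a 2.6-fold lower number (0.42 log units; beyond the scatter) from compound 2 to compound 1 and a 1.3-fold lower number (0.11 log units; within the scatter) from compound 3 to compound 4, 2.0-fold (0.31 log units) apart, within the scatter of two such steps This shows that the two results are compatible with one shared step size, but it does not show that the change carries over from one core to another, as only two pairs are available, they sit at different places, and only the step from compound 2 to compound 1 stands beyond the scatter.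

The compounds shown leave open whether a chlorine or a methoxy group in place of the fluorine would behave as the fluorine does on either benzyl arm, and whether a plain phenyl with no fluorine would give a number apart from those of compound 3 and compound 4. Each of the two places also appears on one core only in these compounds, which leaves the part played by place and the part played by core unseparated.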